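A few compounds are considered here, and "the series" means these few. Any claim that something is new, unique, unknown or untested is made for them only; others in the source may bear on it.

Measured so far in a functional assay on Hep cells (Homo sapiens) for cytotoxicity, read by sulforhodamine B assay, with a stated time of 48 h; on this read-out higher numbers stand for weaker inhibition and lower numbers for stronger inhibition:
- Compound 1 `C=CCOc1ccc(F)cc1C(=O)c1cccnc1`: > 100000 nM, a limit
- Compound 2 `C=CCOc1cc(Br)ccc1C(=O)c1cccnc1`: > 100000 nM, a limit

Compound 1 has no exact number, only a limit: in this assay compound 1 reads > 100000 nM. Compound 2 also gives only a limit, > 100000 nM. The record so far is thus (the limit of > 100000 nM in this assay, at which 2 of the 2 values shown sit).

Compound 3 `O=C(c1cccnc1)c1cc(F)ccc1O` has not yet been measured. It differs from compound 1 by a single change, hydrogen in place of allyl on an oxygen on an aromatic ring. Cut one bond further out, the same difference reads allyloxy to hydroxy. Going by the values given here, no measured pair shows what this change does. The expectation therefore rests on compound 1, whose reading is the limit > 100000 nM. In this assay, the expected outcome is no step beyond the scatter, or a modest one toward stronger inhibition, and a reading that again gives only a limit is quite likely. The estimated step is an at least 1.2-fold lower number from compound 1 to compound 3 (0.09 log units; that floor lies within the scatter). For compound 3 the estimated value is 80000 nM, with an expected range from 30000 nM to 200000 nM.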

Compound 3, half-maximal inhibitory concentration: 12000 nM
Estimate against measurement, compound 3: 6.7-fold (0.82 log units) above; measured number outside the range, below it.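

In this assay, putting hydrogen in place of allyl on the oxygen on an aromatic ring gives the only exact reading among the compounds shown, and the change comes with an at least 8.3-fold lower number from compound 1 to compound 3 (0.92 log units; beyond the scatter) as its step. Going by these compounds alone, this shows that the read-out responds to what sits on this oxygen, which compound 1 and compound 2 could not show, as both of them stop at a limit and offer no measured pair. As far as these compounds go, the true size of the step remains unknown and only its floor can be stated, since the starting reading of compound 1 is a limit and not a number: the limit of > 100000 nM in this assay, at which 2 of the 3 values shown sit.

The compounds shown leave open whether the stronger inhibition belongs to the free hydroxy itself or only to the loss of the allyl, a question that a methyl or a saturated propyl on the same oxygen, or an amine in place of the hydroxy, would help to settle. From the compounds shown here alone, it also remains open whether the same change from allyloxy to hydroxy acts in the same way on the bromine-bearing compound 2.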